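Replacing the urea of compound 2 with a benzamide

The source may hold more compounds than are shown below. What is called first, only, known or untested is meant among the compounds shown, and "the series" means these compounds.

Measured so far:
compound 1 `O=C(Nc1cccc(-n2cc(-c3ccncc3)c(-c3cc(O)cc(Cl)c3)n2)c1)Nc1ccc(Cl)c(Cl)c1` gives -57.3%
compound 2 `COc1cc(Cl)cc(-c2nn(-c3cccc(NC(=O)Nc4ccc(Cl)c(Cl)c4)c3)cc2-c2ccncc2)c1` gives 9.22%

Within the data shown here, in a functional assay on HCT-116 cells (Homo sapiens) for inhibition, read by sulforhodamine B assay, with a stated time of 48 h, tested at 10 uM (on this read-out lower numbers stand for a stronger effect and higher numbers for a weaker effect at the one concentration tested), compound 2 stands as the highest of the two numbers, its nearest neighbour being compound 1, which lies a number 66.5 percentage points higher from compound 1 to compound 2 (beyond the scatter) away across the one measured step, a change of methyl in place of hydrogen on an oxygen on an aromatic ring. Compound 3 `COc1cc(Cl)cc(-c2nn(-c3cccc(NC(=O)c4cccc(C(F)(F)F)c4)c3)cc2-c2ccncc2)c1` has not yet been measured. It differs from compound 2 in one place: 3-(trifluoromethyl)phenyl in place of (3,4-dichlorophenyl)amino on a carbonyl carbon. Among the measured compounds shown here, no measured step touches this part of the molecule; the single step recorded, from compound 1 to compound 2, concerns the oxygen substituent on the other aromatic ring and says nothing about the carbamoyl end. The expectation for compound 3 therefore rests on compound 2 alone, with wide uncertainty in either direction. Compound 3 is estimated to give 25% (range -25% to 65%), which would mean an expected step of a number 15.8 percentage points higher from compound 2 to compound 3 (beyond the scatter), not clearly beyond the scatter.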

Compound 3, a percentage reported as activity, at one concentration (the size of the read-out at that concentration, not a potency): 34.1%
Beside the measured number, compound 3's estimate is 9.1 percentage points below it; low and high end bracket the measured number.
By their numbers in this assay, from the lowest: compound 1; then compound 2; then compound 3.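

In this assay, the carbonyl end of the molecule responds to change: putting 3-(trifluoromethyl)phenyl in place of (3,4-dichlorophenyl)amino on the carbonyl carbon gives a number 24.9 percentage points higher from compound 2 to compound 3 (beyond the scatter), a move toward a weaker effect at the one concentration tested. Among these compounds, this is the first reading at this end, since the only earlier step concerned the oxygen substituent on the other aromatic ring. The change replaces the amino nitrogen, with its hydrogen-bond donor, and the two chlorines in a single move, so the step cannot be assigned to either part, and no other measurement offers an explanation for it.

The compounds shown leave open how the linking nitrogen and the ring substituents each contribute, a question that a urea carrying 3-(trifluoromethyl)phenyl or a benzamide carrying 3,4-dichlorophenyl could separate. They also leave open whether the free hydroxyl of compound 1 keeps its stronger effect on the benzamide series, and how a ring bearing an amine or a carboxylic acid would behave on the same carbonyl carbon.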